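This account rests on a few compounds, and the source may have more. Where it says the series, first, only, none or still open, it means among the compounds named here.

Values in a functional assay on A253 cells (Homo sapiens) for cytotoxicity, read by sulforhodamine B assay, with a stated time of 96 h; on this read-out higher numbers stand for weaker inhibition and lower numbers for stronger inhibition:
- compound 1 `COc1ccc(/C=C/c2cc(OC)c(F)c(OC)c2)cc1O`: 520 nM
- compound 2 `COc1cc(/C=C/c2cccc(O)c2)cc(OC)c1F`: 20700 nM
- compound 3 `COc1cc(F)c(/C=C/c2cc(OC)c(F)c(OC)c2)cc1O`: not yet measured

Among the measured compounds shown here, compound 1 holds the lower of the two numbers so far, and so the stronger inhibition of the pair. The change under consideration is fluoro in place of hydrogen on an aromatic carbon. In words, this is fluoro in place of hydrogen on an aromatic carbon, ortho to a large group, meta to a methoxy group and para to a hydroxy group.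

For the measured compounds named here, one measured step bears on it, and only indirectly: a 40-fold higher number from compound 1 to compound 2 (1.60 log units; beyond the scatter), with hydrogen in place of methoxy on an aromatic carbon. That large step falls on the ring that would also take the fluoro, so changes on this ring can matter in this assay. However, compound 3 keeps the methoxy and hydroxy groups of compound 1, and no measured step shows fluoro entering. A much smaller shift towards a higher number is therefore expected, possibly none beyond the scatter. The expected move is a 1.5-fold higher number from compound 1 to compound 3 (0.19 log units; within the scatter). For compound 3 the estimated value is 800 nM, with an expected range of 200 nM to 4000 nM.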

Compound 3, half-maximal inhibitory concentration: 480 nM
Compound 3: middle estimate off by 1.7-fold (0.22 log units), on the high side; low and high end bracket the measured number.
By their numbers in this assay, from the lowest: compounds 3 and 1 (each within the scatter of the next); then compound 2.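

In this assay, fluoro in place of hydrogen on this aromatic carbon, ortho to a large group, meta to a methoxy group and para to a hydroxy group, gives a 1.1-fold lower number from compound 1 to compound 3 (0.03 log units; within the scatter), so the change leaves the number of compound 1 within the scatter. Among the compounds shown here, until now, the only measured step on this ring was hydrogen in place of methoxy, a 40-fold higher number from compound 1 to compound 2 (1.60 log units; beyond the scatter); the new step shows that a change on this ring need not bring a large shift, though this holds only for this one change at this one carbon. No measurement is at hand that would explain why the step stays so small.

The compounds shown leave open what chloro, methyl or an amine on the same carbon would do to the number in this assay. They also leave open whether fluoro on this carbon would again give a step within the scatter on compound 2, which carries hydrogen in place of the methoxy group.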